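The compounds below may be only part of what the source reports. "The series", "measured", "known", "first", "only" and "open" are said of these compounds alone.

Of the compounds shown here, three that share one core have been measured in an assay on isolated protein for inhibition of Fatty-acid amide hydrolase 1 (Homo sapiens); a lower number here means a stronger inhibitor, a higher number a weaker inhibitor. Compound 1 `CCCCCCCC/C=C\CCCCCCC(=O)c1ncc(-c2ccco2)o1` carries a furan-2-yl on the core and gives 54 nM. Compound 2 `CCCCCCCC/C=C\CCCCCCC(=O)c1ncco1`, with hydrogen at the same place, gives 17 nM. Compound 3 `CCCCCCCC/C=C\CCCCCCC(=O)c1ncc(-c2ccccc2)o1`, with a phenyl there, gives 320 nM, the highest of the three numbers; both steps that lead to it go upward, a 5.9-fold higher number from compound 1 to compound 3 (0.77 log units; beyond the scatter) and a 19-fold higher number from compound 2 to compound 3 (1.27 log units; beyond the scatter), and both lie beyond the scatter.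

The unmeasured compound 4 `CCCCCCCC/C=C\CCCCCCC(=O)c1ncc(-c2cccnc2)o1` differs from compound 3 in one place: pyridin-3-yl in place of phenyl on an aromatic carbon. The two steps into compound 3 bear on this change, since each exchanges the group on that same aromatic carbon. The furan-2-yl of compound 1, a five-membered ring with one hetero atom, gave a lower number than the phenyl of compound 3; hydrogen gave a lower one still. Pyridin-3-yl is again a six-membered ring, but with one hetero atom and one hydrogen-bond acceptor, as the furan-2-yl had. The expectation is therefore a modest downward step in this assay, smaller than the step from compound 1 to compound 3. Compound 4 is expected to give 150 nM, within 50 nM to 450 nM, an expected step of a 2.1-fold lower number from compound 3 to compound 4 (0.33 log units; beyond the scatter).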

Compound 4, inhibition constant: 61 nM
Compound 4: middle estimate off by 2.5-fold (0.39 log units), on the high side; the range from low to high includes it.
By their numbers in this assay, from the lowest: compound 2; then compounds 1 and 4 (each within the scatter of the next); then compound 3.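

In this assay, the exchange of phenyl for pyridin-3-yl gives a 5.2-fold lower number from compound 3 to compound 4 (0.72 log units; beyond the scatter) at this position, with the heavy-atom count unchanged and one ring carbon replaced by nitrogen, so a six-membered aromatic ring here does not in itself carry the number of compound 3. The earlier compounds could not separate ring size from the presence of a hetero atom, but a 1.1-fold higher number from compound 1 to compound 4 (0.05 log units; within the scatter) now places the six-membered pyridin-3-yl level with the five-membered furan-2-yl, and among these three ring groups only phenyl, the one without a hetero atom, stands apart. Hydrogen on this carbon still gives the lowest number, with a 3.6-fold higher number from compound 2 to compound 4 (0.55 log units; beyond the scatter) showing that the pyridin-3-yl does not reach the number of compound 2.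

The compounds shown leave open whether the place of the nitrogen matters, as pyridin-2-yl or pyridin-4-yl would show, and whether an amine or a carboxylic acid on the ring would move the number further. Nothing given here accounts for these differences.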